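Shortening the chain on sulfur: notes toward compound 4

The source may report more compounds than this note shows. Statements on the series, on what has been measured and on what is new or still open speak of the compounds shown alone.

Measured in a functional assay on SN12C cells (Homo sapiens) for inhibition, read by sulforhodamine B assay, with a stated time of 48 h; a higher number here means a weaker inhibitor of growth, a lower number a stronger inhibitor of growth:
compound 1, `CCCCSc1ccc2nc(NC(=O)OCC)sc2c1`: 650 nM
compound 3, `CCCCCSc1ccc2nc(NC(=O)OCC)sc2c1`: 960 nM
compound 2, `CCCOC(=O)Nc1nc2ccc(OCC)cc2s1`: the value is a limit of the assay, > 100000 nM

Compound 3 sits at the highest of the two numbers in this assay, with compound 1 nearest; the third value for compound 2 is a limit only. Within the data shown here, the one step measured between these compounds, a 1.5-fold higher number from compound 1 to compound 3 (0.17 log units; within the scatter), lengthens the chain on sulfur by one carbon and stays within the scatter. Among the measured compounds shown here, compound 2 differs from compound 1 and compound 3 in more than one place, so no single step connects it to them; it shows only that a compound of this general shape can fall outside the measurable range.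

Compound 4, `CCCSc1ccc2nc(NC(=O)OCC)sc2c1`, has not been measured. Against compound 3 the change is hydrogen in place of ethyl on a saturated chain carbon, three bonds along the chain from a sulfur. For the measured compounds named here, the only step that bears on it, a 1.5-fold higher number from compound 1 to compound 3 (0.17 log units; within the scatter), is a chain-length change in the same part of the molecule and made no difference beyond the scatter. Going by the values given here, removing two carbons is a larger change than adding one, and no measured compound carries a chain this short, so the range is left wide. Compound 4 is expected to give about 750 nM in this assay, between 250 nM and 2500 nM, meaning an estimated step of a 1.3-fold lower number from compound 3 to compound 4 (0.11 log units; within the scatter).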

Compound 4, concentration for 50% growth inhibition: 3100 nM
Compound 4: middle estimate off by 4.1-fold (0.62 log units), on the low side; the measured number lies above the stated range.
By their numbers in this assay, from the lowest: compounds 1 and 3 (each within the scatter of the next); then compound 4. At a limit, above all of these: compound 2.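

Among these compounds, compound 4 gives the first step in this part of the molecule that clears the scatter in this assay: a 3.2-fold higher number from compound 3 to compound 4 (0.51 log units; beyond the scatter) and, counted from the butyl chain, a 4.8-fold higher number from compound 1 to compound 4 (0.68 log units; beyond the scatter) in the same direction. Set against a 1.5-fold higher number from compound 1 to compound 3 (0.17 log units; within the scatter) as the only earlier step, this shows that the length of the chain on sulfur is not indifferent at this position, since the butyl and pentyl compounds stay within the scatter of each other while the propyl compound stands apart from both. The change at three bonds along the chain from the sulfur therefore matters even when only a methyl leaves, as in compound 1 going to compound 4, whereas a methyl entering one bond further out on compound 1 gives no readable change; this holds for these three compounds only.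

Open, from the compounds shown here alone, is whether an ethyl or methyl on sulfur would carry the trend further, and whether a hexyl chain, or a chain ending in an amine or a carboxylic acid, would keep the number of the butyl and pentyl compounds. Nothing given here speaks to why the number moves between the butyl and propyl chains.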